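D(4) agonist efficacy series: cyano replacing methyl on the amide aryl

A few compounds are considered here, and "the series" means these few. Any claim that something is new, unique, unknown or untested is made for them only; others in the source may bear on it.

Measured so far:
- compound 1 `Cc1cc(C(=O)NCN2CCC(c3cccc[n+]3[O-])CC2)ccc1F`: 67%
- compound 2 `Cc1cccc(C(=O)NCN2CCC(c3cccc[n+]3[O-])CC2)c1`: 77%

Compound 2 stands highest of the two numbers in a functional assay on HEK293 cells for agonist activity at D(4) dopamine receptor (Homo sapiens), read by FLIPR (on this read-out lower numbers stand for smaller maximal responses and higher numbers for larger maximal responses), though only with its nearest neighbour compound 1 at a distance within the scatter. Among the compounds with values here, the one measured step, a number 10 percentage points higher from compound 1 to compound 2 (within the scatter), lies within the scatter and concerns a different change on the same ring, so it bears only loosely on the new compound.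

Compound 3 `N#Cc1cccc(C(=O)NCN2CCC(c3cccc[n+]3[O-])CC2)c1` differs from compound 2 in this way: cyano in place of methyl on an aromatic carbon. Within the data shown here, no measured step swaps a methyl for a cyano, so nothing points to a direction. The expectation is therefore a step of about a number 5 percentage points lower from compound 2 to compound 3 (within the scatter) in this assay, not beyond the scatter. Compound 3 is estimated to give 72% in this assay, within a range from 50% to 92%.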

Compound 3, largest response reached (reported as efficacy), in percent of the reference or control that the assay uses: 69%
Beside the measured number, compound 3's estimate is 3 percentage points above it; measured number inside the range.
By their numbers in this assay, from the lowest: compounds 1, 3 and 2 (each within the scatter of the next).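

In this assay the change from 3-methylphenyl to 3-cyanophenyl gives a number 8 percentage points lower from compound 2 to compound 3 (within the scatter) and so shows that, at this position, a nitrile can stand in place of methyl without a shift in maximal response beyond the scatter. Exchanging the whole 4-fluoro-3-methylphenyl for 3-cyanophenyl gives a number 2 percentage points higher from compound 1 to compound 3 (within the scatter) and so leaves all three amides within the scatter of one another on this read-out. Nothing available here bears on why the response holds across this change.

Still open, on these data alone, is whether a group of another kind at this position, such as an amine, a carboxylic acid or a methoxy group, would move the response beyond the scatter. Also open, as far as these compounds go, is whether a fluoro on the 3-cyanophenyl ring would leave the response within the scatter of compound 3.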